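Swapping the triazole substituent on compound 2: what to expect

The source may report more compounds than this note shows. Statements on the series, on what has been measured and on what is new or still open speak of the compounds shown alone.

Compound 2 `COc1ccc([C@@H]2CC(=O)c3c(O)cc(OCc4cn(Cc5cccc(C#N)c5)nn4)cc3O2)cc1O` gives 18000 nM in a functional assay on RAW264.7 cells (Mus musculus) for inhibition, read by Griess assay, with stated times of 2 h and 24 h (a higher number here means a weaker inhibitor, a lower number a stronger inhibitor), the second highest of three numbers. Compound 1 `C#CCOc1cc(O)c2c(c1)O[C@H](c1ccc(OC)c(O)c1)C/C2=N\O` gives 19100 nM, within the scatter of compound 2, while compound 3 `COc1ccc([C@@H]2C/C(=N\O)c3c(O)cc(OCc4cn(CC5CC5)nn4)cc3O2)cc1O` gives 6320 nM, a lower number beyond the scatter. Among the measured compounds shown here, the only measured step is a 3.0-fold lower number from compound 1 to compound 3 (0.48 log units; beyond the scatter), a change at a different place from the one considered here. Compound 4 `COc1ccc([C@@H]2CC(=O)c3c(O)cc(OCc4cn(C5CCCCC5)nn4)cc3O2)cc1O` differs from compound 2 by cyclohexyl in place of 3-cyanobenzyl on an aromatic nitrogen. For the measured compounds named here, no measured step touches this position, so the expectation leans on the general spread of the three numbers. Compound 4 is therefore expected to give 12000 nM, with a range of 5000 nM to 30000 nM, a step of a 1.5-fold lower number from compound 2 to compound 4 (0.18 log units; within the scatter) that is expected to stay close to the scatter.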

Compound 4, half-maximal inhibitory concentration: 15600 nM
The estimate for compound 4 lay 1.3-fold (0.11 log units) below the measured number, within the range that was stated.
By their numbers in this assay, from the lowest: compound 3; then compounds 4, 2 and 1 (each within the scatter of the next).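

Among the compounds shown here, the first measured step at this position is a 1.2-fold lower number from compound 2 to compound 4 (0.06 log units; within the scatter). In this assay, therefore, replacing 3-cyanobenzyl with cyclohexyl on the aromatic nitrogen, which removes the nitrile and the aromatic ring of that group, leaves the number within the scatter. No available evidence explains this result.

Compound 3 differs from compound 2 and compound 4 in more than one place, which leaves the effect of its cyclopropylmethyl group at this nitrogen unresolved. Going by these compounds, how an amine or a carboxylic acid on this nitrogen would read also remains open.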